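A few compounds are considered here, and "the series" means these few. Any claim that something is new, unique, unknown or untested is made for them only; others in the source may bear on it.

Measured so far:
- compound 1 `O=C(NCc1ccc(S(=O)(=O)N2CCCCC2)cc1)c1cc2cnccc2o1` — 140 nM in an assay for inhibition of Nicotinamide phosphoribosyltransferase (Homo sapiens), read by mass spectrometry, with stated times of 15 min and 30 min; on this read-out lower numbers stand for stronger inhibition and higher numbers for weaker inhibition
- compound 2 `O=C(NCc1ccc(S(=O)(=O)N2CCCCC2)cc1)c1ccc2nc[nH]c2c1` — 310 nM in this assay

Among the measured compounds shown here, compound 2 stands at the higher of the two numbers in this assay; the only measured step is a 2.2-fold higher number from compound 1 to compound 2 (0.35 log units; beyond the scatter), a modest change on the carbonyl carbon. Compound 3 `O=C(NCc1ccc(S(=O)(=O)N2CCCCC2)cc1)c1cc2cccnc2s1` is the next variation at the same place: a group of 9 heavy atoms (7 carbon, 1 nitrogen, 1 sulfur; one five-membered aromatic ring with 1 hetero atom, one six-membered aromatic ring with 1 hetero atom) in place of a group of 9 heavy atoms (7 carbon, 2 nitrogen; one five-membered aromatic ring with 2 hetero atoms, one six-membered aromatic ring of carbon only), on a carbonyl carbon. For the measured compounds named here, no measured pair isolates this exact exchange, but compound 1 already shows that a bicyclic group built from a five-membered ring with one hetero atom fused to a six-membered ring with one hetero atom gives the lower number, so the step from compound 2 to compound 3 is read as a return towards that arrangement rather than a new departure. The expected step is therefore modest and downward, a 2.1-fold lower number from compound 2 to compound 3 (0.32 log units; beyond the scatter), with the number for compound 3 expected near that of compound 1. Estimate for compound 3 in this assay: 150 nM, range 60 nM to 400 nM.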

Compound 3, half-maximal inhibitory concentration: 8 nM
The estimate for compound 3 lay 19-fold (1.27 log units) above the measured number; measured number outside the range, below it.
By their numbers in this assay, from the lowest: compound 3; then compound 1; then compound 2.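

In this assay, the group on the carbonyl carbon proves far more sensitive than the first pair indicated: replacing 1H-benzimidazol-6-yl with the sulfur-containing group gives a 39-fold lower number from compound 2 to compound 3 (1.59 log units; beyond the scatter). Matching ring counts do not settle the number, since the groups of compound 1 and compound 3 both have one five-membered aromatic ring with 1 hetero atom and one six-membered aromatic ring with 1 hetero atom, yet the exchange gives an 18-fold lower number from compound 1 to compound 3 (1.24 log units; beyond the scatter). No supporting measurement bears on the origin of either step.

The groups of compound 1 and compound 3 differ in more than oxygen versus sulfur, so the contribution of the sulfur itself remains unresolved. Also open, on these data alone, is whether a benzothiophene group, with sulfur but no ring nitrogen, would retain the low number.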